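The source may hold more compounds than are shown below. What is called first, only, known or untested is meant among the compounds shown, and "the series" means these compounds.

Measured compounds and their values in an ADME assay on the whole organism (Mus musculus, strain Swiss Webster) for pharmacokinetics, read by LC-MS, at a dose of 50 mg/kg by the oral route; a lower number here means less compound in the circulation, a higher number more compound in the circulation at the dose given:

Compound 1, `O=C(Nc1ccc(F)c(-c2nc3ncc(-c4cc(F)ccc4F)cc3[nH]2)c1)N1CCCC1`: 5620 ng.h/mL
Compound 2, `O=C(Nc1ccc(F)c(-c2nc3ncc(-c4cc(F)cc(F)c4)cc3[nH]2)c1)N1CCCC1`: 9400 ng.h/mL
Compound 3, `Cc1nc(C)c(C(=O)Nc2ccc(F)c(-c3nc4ncc(-c5ccccc5Cl)cn4n3)c2)o1`: 309000 ng.h/mL

Compound 1 stands at the low end of these three numbers. Going by the values given here, its nearest neighbour is compound 2, whose value lies within the scatter of it; compound 3, which differs from compound 1 in several places at once, gives a far larger number, and no single step connects the two.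

The unmeasured compound 4, `O=C(Nc1ccc(F)c(-c2nc3ncc(-c4ccc(F)c(F)c4)cc3[nH]2)c1)N1CCCC1`, differs from compound 1 in one place: 3,4-difluorophenyl in place of 2,5-difluorophenyl on an aromatic carbon.

Among the compounds with values here, the only measured step that resembles this change is the one from compound 1 to compound 2, where one difluorophenyl replaces another on the same carbon: a 1.7-fold higher number from compound 1 to compound 2 (0.22 log units; within the scatter). That step did not move the number beyond the scatter, so moving the two fluorines to a third arrangement is expected to leave the number close to that of compound 1.

For compound 4 the expected step is a 1.2-fold higher number from compound 1 to compound 4 (0.10 log units; within the scatter). Compound 4 is therefore estimated at 7000 ng.h/mL, with a range from 3000 ng.h/mL to 16000 ng.h/mL.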

Compound 4, area under the concentration-time curve: 12000 ng.h/mL
Estimate against measurement, compound 4: 1.7-fold (0.23 log units) below; measured number inside the range.
By their numbers in this assay, from the lowest: compounds 1, 2 and 4 (each within the scatter of the next, the first and the last beyond it); then compound 3.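

In this assay a rearrangement of the two fluorines on this carbon's phenyl ring can now reach just past the usual scatter: 3,4-difluorophenyl in place of 2,5-difluorophenyl gives a modest step (a 2.1-fold higher number from compound 1 to compound 4 (0.33 log units; beyond the scatter)), whereas the earlier swap at this position stayed within it. Against the 3,5-difluorophenyl group, the new arrangement cannot be told apart (a 1.3-fold higher number from compound 2 to compound 4 (0.11 log units; within the scatter)), so only the two ends of this small series separate. Nothing available explains why the fluorine arrangement matters here.

The one-place comparisons cover only difluorophenyl groups, leaving open what a phenyl ring carrying a methoxy group or an amine would do at this carbon. Compound 3 differs from these compounds in several places, so its much larger number cannot be assigned to any single change.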